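Bromo removal from compound 2 in the series

The source may hold more compounds than are shown below. What is called first, only, known or untested is meant among the compounds shown, and "the series" means these compounds.

Compound 1 `C=C1C[C@]23C[C@@]1(O)CC[C@H]2c1cc(Br)c(O)c(C)c1[C@@H]3Cn1cc(-c2ccccc2)nn1`, compound 2 `C=C1C[C@]23C[C@@]1(O)CC[C@H]2c1cc(Br)c(O)c(C)c1[C@@H]3Cn1cc(-c2ccc(Cl)cc2)nn1` and compound 3 `C=C1C[C@]23C[C@@]1(O)CC[C@H]2c1cc(Br)c(O)c(C)c1[C@@H]3Cn1cc(-c2ccc(F)cc2)nn1` share one core and differ only by chloro or fluoro in place of hydrogen on an aromatic carbon. For the measured compounds named here, in a functional assay on SW480 cells (Homo sapiens) for cytotoxicity, read by MTT assay, with a stated time of 4 days (on this read-out lower numbers stand for stronger inhibition and higher numbers for weaker inhibition), compound 2 gives 18000 nM, the only number among the three. In this assay compound 1 reaches only a limit, > 20000 nM. In this assay compound 3 likewise sits at a limit, > 20000 nM. The measured steps are accordingly faint: an at least 1.1-fold lower number from compound 1 to compound 2 (0.04 log units; that floor lies within the scatter), an at least 1.1-fold higher number from compound 2 to compound 3 (0.04 log units; that floor lies within the scatter), and a step that the two limits leave unreadable from compound 1 to compound 3, all resting on (the limit of > 20000 nM in this assay, at which 2 of the 3 values shown sit).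

Compound 4 `C=C1C[C@]23C[C@@]1(O)CC[C@H]2c1ccc(O)c(C)c1[C@@H]3Cn1cc(-c2ccc(Cl)cc2)nn1` is not yet measured. It differs from compound 2 by hydrogen in place of bromo on an aromatic carbon. Going by the values given here, none of the measured steps touches this position, so none gives a reading for the change. Among the compounds with values here, with compound 2 at 18000 nM the only number in hand, the step expected for compound 4 is a 1.1-fold higher number from compound 2 to compound 4 (0.05 log units; within the scatter), nothing beyond the scatter. Compound 4 is therefore estimated at 20000 nM, within 8000 nM to 50000 nM, with a real chance that this assay again returns only a limit.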

Compound 4, half-maximal inhibitory concentration: > 20000 nM
Compound 4 was reported as a limit; the forecaster's own chance of this, stated with the estimate: 50%; the middle value lies on the limit itself.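

For the compounds shown here, the aromatic carbon ortho to a hydroxy group now has its first reading, since the earlier steps touched only the other aromatic ring: hydrogen in place of bromo gives an at least 1.1-fold higher number from compound 2 to compound 4 (0.04 log units; that floor lies within the scatter) in this assay. This reading neither shows that the bromo matters nor shows that it can be lost, as nothing beyond the scatter can be claimed for the change. Compound 4 stands at a limit, so the step is a floor only and its real size cannot be read: the limit of > 20000 nM in this assay, at which 3 of the 4 values shown sit.

Still open, on these data alone, is whether another group on this carbon, such as an amine, a nitrile or a carboxylic acid, would give a number rather than a limit. The same change also remains without a reading on any compound pair where both values are numbers.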